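Swapping the aryl group on a weak growth inhibitor

This account rests on a few compounds, and the source may have more. Where it says the series, first, only, none or still open, it means among the compounds named here.

Compound 1 `Cc1ccc(Nc2ncc(C(F)(F)F)c(N3Cc4cccc(N(C)S(C)(=O)=O)c4C3)n2)cc1C` was tested in a functional assay on U-87MG ATCC cells for antiproliferative activity against U-87 MG (Homo sapiens), read by spectrophotometry, with a stated time of 2 days; a higher number here means a weaker inhibitor of growth, a lower number a stronger inhibitor of growth. In this assay compound 1 reaches only the limit of > 30000 nM, which is not a number. Compound 2 `COc1ccc(C(F)(F)F)cc1Nc1ncc(C(F)(F)F)c(N2Cc3cccc(N(C)S(C)(=O)=O)c3C2)n1` likewise sits at the limit of > 30000 nM in this assay. The step from compound 1 to compound 2 a step that the two limits leave unreadable from compound 1 to compound 2 cannot be sized because of the limit of > 30000 nM in this assay, at which 2 of the 3 values shown sit. Compound 3 `CN(c1cccc2c1CN(c1nc(Nc3cc(C(F)(F)F)cc(C(F)(F)F)c3)ncc1C(F)(F)F)C2)S(C)(=O)=O` does give a number, 16800 nM in this assay, a weak inhibition of growth. Compound 4 `COc1cc(Nc2ncc(C(F)(F)F)c(N3Cc4cccc(N(C)S(C)(=O)=O)c4C3)n2)cc(C(F)(F)F)c1` has not yet been measured. It differs from compound 1 in one place: 3-methoxy-5-(trifluoromethyl)phenyl in place of 3,4-dimethylphenyl on a nitrogen on an aromatic ring. Compound 2 carries another group on that nitrogen on an aromatic ring and stays at the limit, and compound 3 carries yet another and gives only weak inhibition, so compound 4 is expected to remain a weak inhibitor in this assay. For compound 4 the expected step of an at least 1.2-fold lower number from compound 1 to compound 4 (0.07 log units; that floor lies within the scatter) is small and may itself be hidden by the limit. Compound 4 is estimated at 25000 nM, between 8000 nM and 60000 nM.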

Compound 4, concentration for 50% growth inhibition: > 30000 nM
Compound 4 gave a limit, no number (the forecaster's own chance of this, stated with the estimate: 55%); middle value at least 1.2-fold (0.07 log units) away from the limit.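

Compound 4 shows that 3-methoxy-5-(trifluoromethyl)phenyl on this nitrogen, like the 2-methoxy-5-(trifluoromethyl)phenyl of compound 2, ends at a limit and not at a number, so among these four compounds only compound 3 gives a number in this assay. Methoxy in place of trifluoromethyl on an aromatic carbon is the first change here that can be sized against a number, and it gives an at least 1.7-fold higher number from compound 3 to compound 4 (0.25 log units; that floor lies within the scatter), so this step alone does not yet show a real loss of growth inhibition, although the true gap could be larger. The steps to compound 4 from compound 1 and from compound 2 cannot be read, because both ends of each are limits: the limit of > 30000 nM in this assay, at which 3 of the 4 values shown sit.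

Going by these compounds, whether an amine or a carboxylic acid on this phenyl ring would give a clearly stronger inhibitor stays open. So does whether any change to the aryl group alone can bring the shared core far below the limit.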